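Cyclopentylmethyl in Place of Isopropyl on the Ketone

The source may report more compounds than this note shows. Statements on the series, on what has been measured and on what is new or still open speak of the compounds shown alone.

Of the compounds shown here, two have been measured in an assay on HEK293 cells for positive allosteric modulation of metabotropic glutamate receptor 3 (Rattus norvegicus), read by thallium flux, with a stated time of 2.5 min; on this read-out lower numbers stand for smaller maximal responses and higher numbers for larger maximal responses. Compound 1 `Cc1c(OCCCCOc2ccc(C(=O)O)c(Cl)c2)ccc(C(=O)CC2CCCC2)c1O` gives 40% there, while compound 2 `Cc1cc(C(=O)O)ccc1OCCCCOc1ccc(C(=O)C(C)C)c(O)c1C` gives 25.2%, the lower of the two numbers and a gap beyond the usual scatter. Compound 3 `Cc1cc(C(=O)O)ccc1OCCCCOc1ccc(C(=O)CC2CCCC2)c(O)c1C` has not been measured; it differs from compound 2 by cyclopentylmethyl in place of isopropyl on a carbonyl carbon. Compound 1 also carries the cyclopentylmethyl group and reaches 40%, which supports an upward expectation. The step is expected to be a number 12.8 percentage points higher from compound 2 to compound 3 (beyond the scatter), a rise beyond the scatter. Compound 3 is therefore estimated at 38%, within 25% to 52%.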

Compound 3, largest response reached (reported as percent of maximum), in percent of the reference or control that the assay uses: 28.4%
Compound 3: middle estimate off by 9.6 percentage points, on the high side; low and high end bracket the measured number.
By their numbers in this assay, from the lowest: compounds 2 and 3 (each within the scatter of the next); then compound 1.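

In this assay, cyclopentylmethyl in place of isopropyl on a carbonyl carbon gives a number 3.2 percentage points higher from compound 2 to compound 3 (within the scatter), so the larger group on the ketone does not by itself separate these two compounds. The clear difference comes instead with 4-carboxy-2-methylphenyl in place of 4-carboxy-3-chlorophenyl on an oxygen on a saturated carbon, which gives a number 11.6 percentage points lower from compound 1 to compound 3 (beyond the scatter). No supporting evidence explains either step.

From the compounds shown here alone, whether the ketone change stays this small alongside 4-carboxy-3-chlorophenyl remains open. So does the outcome with a benzyl or tert-butyl group on that carbonyl carbon.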